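Ethyl to Cyclopropyl: Expected Change in Lipophilicity

A few compounds are considered here, and "the series" means these few. Any claim that something is new, unique, unknown or untested is made for them only; others in the source may bear on it.

Measured compounds:
Compound 1, `CCCC(Oc1ccc(-n2cc(C(F)(F)F)cn2)c(C)c1)c1ccc(C(=O)NCCC(=O)O)cc1`, gives 2.6 in a physicochemical assay for lipophilicity, using the shake flask method, at pH 7.4; on this read-out lower numbers stand for lower lipophilicity and higher numbers for higher lipophilicity.
Compound 2, `CCC(Oc1ccc(-n2cc(C(F)(F)F)cn2)cc1)c1ccc(C(=O)NCCC(=O)O)cc1`, gives 1.9 in this assay.

Compound 2 holds the lower of the two measured numbers; compound 1 sits higher by a gap that lies beyond the usual scatter of repeated measurements. Going by the values given here, compound 1 and compound 2 differ in more than one place, so no single-change step between measured compounds is available, and any expectation for a new compound must rest on the structures themselves.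

Compound 3, `O=C(O)CCNC(=O)c1ccc(C(Oc2ccc(-n3cc(C(F)(F)F)cn3)cc2)C2CC2)cc1`, has not yet been measured. (cyclopropyl in place of ethyl on a saturated chain carbon bound to an aromatic carbon and an oxygen on an aromatic ring). Both the group that leaves and the group that enters are built of carbon only and carry no hydrogen-bond donors or acceptors, so the change is a small one in kind.

The step from compound 2 to compound 3 in this assay is expected to be a modest rise, a number 0.40 log units higher from compound 2 to compound 3 (beyond the scatter), of roughly the size of the scatter itself. For compound 3 the value in this assay is therefore estimated at 2.3, within a range from 1.9 to 2.7.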

Compound 3, distribution coefficient: 1.7
Compound 3: the middle estimate sits 0.60 log units above what was measured; the measured number lies below the stated range.
By their numbers in this assay, from the lowest: compounds 3 and 2 (each within the scatter of the next); then compound 1.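

In this assay, going by these compounds alone, cyclopropyl in place of ethyl on a saturated chain carbon bound to an aromatic carbon and an oxygen on an aromatic ring gives a number 0.20 log units lower from compound 2 to compound 3 (within the scatter) and so provides the first reading of a single change at this position, which the earlier pair, differing in more than one place, could not give. On this read-out the two groups cannot be told apart in this shared core: closing the carbon chain into a three-membered ring leaves a difference that repeated measurements could not separate from ordinary scatter, so the two compounds count as equal here. No measurement is available that would explain this outcome.

What the compounds leave open is whether the same holds on the core of compound 1, which carries a further difference and has no matching cyclopropyl partner among the compounds shown. On these data alone, it is also open how far this position tolerates other groups in this assay, such as a cyclobutyl ring, an isopropyl group or a chain carrying an amine, since a single pair cannot show a trend.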